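Series notes: aryl exchange from compound 2 to compound 3

A few compounds are considered here, and "the series" means these few. Any claim that something is new, unique, unknown or untested is made for them only; others in the source may bear on it.

Measured so far:
compound 1, `CCCCCCC(Sc1nc(Cl)cc(Nc2nc(-c3ccc(C)cc3)cs2)n1)C(=O)O`: 3000 nM
compound 2, `CCCCCCC(Sc1nc(Cl)cc(Nc2nc(-c3cccc4ccccc34)cs2)n1)C(=O)O`: 700 nM

Both numbers come from an assay for inhibition of Polyunsaturated fatty acid 5-lipoxygenase (Homo sapiens), read by HPLC, with a stated time of 10 min; on this read-out lower numbers stand for stronger inhibition and higher numbers for weaker inhibition. Among the compounds with values here, compound 2 holds the lowest number of the two; its nearest neighbour is compound 1, and the only measured step, a 4.3-fold lower number from compound 1 to compound 2 (0.63 log units; beyond the scatter), is a modest one beyond the scatter. Compound 3, `CCCCCCC(Sc1nc(Cl)cc(Nc2nc(-c3ccc(F)cc3F)cs2)n1)C(=O)O`, is not yet measured. Its change from compound 2 is 2,4-difluorophenyl in place of naphthalen-1-yl on an aromatic carbon. Within the data shown here, the one step that bears on this is a 4.3-fold lower number from compound 1 to compound 2 (0.63 log units; beyond the scatter), which links a single-ring group, 4-methylphenyl, to naphthalen-1-yl at the same place. Compound 3 returns to a single six-membered ring, this time 2,4-difluorophenyl, so the number is expected to move back up toward that of compound 1, though nothing measured tells how 2,4-difluorophenyl compares with 4-methylphenyl on this read-out. The step expected is a 3.6-fold higher number from compound 2 to compound 3 (0.55 log units; beyond the scatter), in the direction of weaker inhibition in this assay. For compound 3 the estimate in this assay is 2500 nM, with a range of 800 nM to 8000 nM.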

Compound 3, half-maximal inhibitory concentration: 2500 nM
The estimate for compound 3 equals the measured number at the digits printed; the measured number falls inside the stated range.
By their numbers in this assay, from the lowest: compound 2; then compounds 3 and 1 (each within the scatter of the next).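

In this assay, the exchange of naphthalen-1-yl, with two six-membered aromatic rings of carbon only, for 2,4-difluorophenyl, with one, gives a 3.6-fold higher number from compound 2 to compound 3 (0.55 log units; beyond the scatter), so the lower number of compound 2 does not carry over to this single-ring group. The comparison between the two single-ring groups gives a 1.2-fold lower number from compound 1 to compound 3 (0.08 log units; within the scatter), so 2,4-difluorophenyl and 4-methylphenyl are not told apart at this aromatic carbon of the five-membered ring, and among these three compounds, with none going against it, only the naphthalen-1-yl compound stands apart. No supporting data are available to explain this pattern.

The compounds shown leave open whether the lower number of compound 2 depends on the second aromatic ring itself or on the larger count of heavy atoms in naphthalen-1-yl than in 2,4-difluorophenyl. They also leave open how this position responds to naphthalen-2-yl, which would show whether the point of ring attachment matters, or to a pyridine ring or a methoxy-bearing phenyl ring, which would place a hydrogen-bond acceptor in the group.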